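The source may hold more compounds than are shown below. What is called first, only, known or untested is meant among the compounds shown, and "the series" means these compounds.

Measured in an ADME assay on MDBK cells (Bos taurus) for cytotoxicity, read by MTT assay, with a stated time of 96 h; a lower number here means that less compound is tolerated, a higher number that more compound is tolerated:
Compound 1 `COc1ccc(-c2nc3cc(Cl)c(Cl)cc3[nH]2)cc1` gives 2500 nM.
Compound 2 `CC(=O)Nc1ccc(-c2nc3cc([N+](=O)[O-])ccc3[nH]2)cc1` reaches only the assay limit, > 100000 nM.
Compound 3 `CC(=O)Nc1ccc(-c2nc3ccccc3[nH]2)cc1` likewise reaches only the assay limit, > 100000 nM.

From compound 3 to compound 2 the change is nitro in place of hydrogen on an aromatic carbon, and its step is a step that the two limits leave unreadable from compound 3 to compound 2, since (the limit of > 100000 nM in this assay, at which 2 of the 3 values shown sit). Compound 4 `COc1ccc(-c2nc3cc(Cl)c(Cl)cc3[nH]2)c([N+](=O)[O-])c1` carries the same kind of change on compound 1, (nitro in place of hydrogen on an aromatic carbon); here the place is ortho to a large group and meta to a methoxy group, whereas in compound 2 it is part of a fused system, meta and para to a fused ring. The difference between the two cores is not broken down here. Going by the values given here, compound 1 is the only one with a readable number. Given the unreadable a step that the two limits leave unreadable from compound 3 to compound 2, compound 4 is expected to move only modestly, a 1.6-fold higher number from compound 1 to compound 4 (0.20 log units; within the scatter), with an estimated 4000 nM between 1000 nM and 20000 nM in this assay.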

Compound 4, half-maximal cytotoxic concentration: 28000 nM
Estimate against measurement, compound 4: 7.0-fold (0.85 log units) below, and the stated range ends below it.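

In this assay, putting nitro in place of hydrogen on an aromatic carbon of compound 1 gives an 11-fold higher number from compound 1 to compound 4 (1.05 log units; beyond the scatter), so on this core the change clearly goes with more compound being tolerated. The same kind of change from compound 3 to compound 2 cannot be read, because both compounds stand at an assay limit: the limit of > 100000 nM in this assay, at which 2 of the 4 values shown sit. The result therefore does not show whether the change carries over from one core to the other, and the nitro group also sits in a different place on each core.

From the compounds shown here alone, it remains open whether another group in the same place on compound 1, such as an amine or a carboxylic acid, would give a similar step. Whether the nitro group itself matters, or simply any group in that place, also stays unanswered.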